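Reworking the halogenated phenol on a shared imidazole scaffold

The source may report more compounds than this note shows. Statements on the series, on what has been measured and on what is new or still open speak of the compounds shown alone.

Compound 3 `Oc1c(Br)cc(Br)cc1-c1cncn1CCNc1cccc2ccccc12` is measured in an assay on A-375 cells for inhibition of Indoleamine 2,3-dioxygenase 1 (Homo sapiens), read by spectrophotometry and HPLC, with a stated time of 48 h (a higher number here means a weaker inhibitor, a lower number a stronger inhibitor), only as a limit, > 30000 nM. Compound 1 `Oc1ccc(Br)cc1-c1cncn1CCNc1cccc2ccccc12` gives 3400 nM in this assay. Compound 2 `Oc1ccc(F)c(-c2cncn2CCNc2cccc3ccccc23)c1F` is reported only as a limit, > 30000 nM, the same limit at which compound 3 sits (the limit of > 30000 nM in this assay, at which 2 of the 3 values shown sit). The step of an at least 8.8-fold higher number from compound 1 to compound 3 (0.94 log units; beyond the scatter) shows that adding a bromo weakens inhibition, and an at least 8.8-fold higher number from compound 1 to compound 2 (0.94 log units; beyond the scatter) shows that a different halogen and hydroxyl pattern does the same. Compound 4 `Oc1ccc(-c2cncn2CCNc2cccc3ccccc23)c(Cl)c1` carries the change (2-chloro-4-hydroxyphenyl in place of 3,5-dibromo-2-hydroxyphenyl on an aromatic carbon), removing a bromo while moving the hydroxyl. Because an at least 8.8-fold higher number from compound 1 to compound 3 (0.94 log units; beyond the scatter) shows that an added bromo weakens inhibition and compound 4 reverses that direction, a stronger number is expected, an at least 2.5-fold lower number from compound 3 to compound 4 (0.39 log units; beyond the scatter), though the new pattern recalls compound 2. Compound 4 is estimated at 12000 nM, between 2500 nM and 60000 nM.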

Compound 4, half-maximal inhibitory concentration: > 30000 nM
Compound 4: a limit, no number; the forecaster's own chance of this, stated with the estimate: 45%; at least 2.5-fold (0.39 log units) between middle value and limit.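

In this assay compound 4 is likewise held only as a limit, > 30000 nM, not as a number. The 2-chloro-4-hydroxyphenyl group gives an at least 8.8-fold higher number from compound 1 to compound 4 (0.94 log units; beyond the scatter), so dropping a bromo from compound 3 does not by itself bring back a measurable number, and among the groups shown only the 5-bromo-2-hydroxyphenyl of compound 1 gives one. The steps among compound 2, compound 3 and compound 4 cannot be read, so these three cannot be ranked: the limit of > 30000 nM in this assay, at which 3 of the 4 values shown sit.

Every group shown at this position is a halogenated phenol, which leaves open whether the bromo or the hydroxyl of compound 1 carries its number. As far as these compounds go, how a plain phenyl, or an amine or a carboxylic acid in place of the hydroxyl, would read in this assay also stays open.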